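The compounds below may be only part of what the source reports. "The series", "measured", "known", "first", "only" and "open" are said of these compounds alone.

Measured in a functional assay on the whole organism for inhibition, with Rattus norvegicus as the target; a higher number here means that more compound is needed for the effect, a lower number that less compound is needed:
- compound 1 `CC(C)c1ccc(OC(C)(Cc2ccc(Cl)cc2)C(=O)O)cc1`: 1 mg/kg; 1 mg/kg; 1 mg/kg (3 entries)
- compound 2 `CC(C)c1ccc(CC(C)(Oc2ccc(C(C)C)cc2)C(=O)O)cc1`: 5 mg/kg
- compound 3 `COc1ccc(CC(C)(Oc2ccc(C(C)C)cc2)C(=O)O)cc1`: > 10 mg/kg, a limit

Compound 3 has no single number in this assay, and its entry of > 10 mg/kg is a limit of the assay. Of the three values shown, this is the only one that is a limit: the limit of > 10 mg/kg in this assay, at which 1 of the 3 values shown sits.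

The next compound, compound 4 `CC(C)c1ccc(OC(C)(Cc2ccc(-c3ccccc3)cc2)C(=O)O)cc1`, carries phenyl in place of methoxy on an aromatic carbon, para to a large group (phenyl in place of methoxy on an aromatic carbon). Going by the values given here, no measured step makes this exact change. The nearest is an at least 2.0-fold higher number from compound 2 to compound 3 (0.30 log units; that floor lies within the scatter), with methoxy in place of isopropyl. That step is only a floor and lies within the scatter, so it gives a weak lead on direction and none on size.

Methoxy leaves in the new step, and both compounds without it give a number. Compound 1 gives 1 mg/kg; 1 mg/kg; 1 mg/kg (3 entries) and compound 2 gives 5 mg/kg. On the strength of those two values, compound 4 is expected to return a number in this assay rather than a limit, though a limit remains possible.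

The expected change is a move to a lower number, an estimated at least 3.3-fold lower number from compound 3 to compound 4 (0.52 log units; beyond the scatter). For compound 4 the estimated value is 3 mg/kg, with an expected range from 0.7 mg/kg to 10 mg/kg.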

Compound 4, dose for half-maximal effect: 1 mg/kg
Compound 4: middle estimate off by 3.0-fold (0.48 log units), on the high side; measured number inside the range.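

In this assay, going by these compounds alone, phenyl on an aromatic carbon para to a large group gives the first steps at this position that read beyond the scatter: an at least 10-fold lower number from compound 3 to compound 4 (1.00 log units; beyond the scatter) with phenyl in place of methoxy, and a 5.0-fold lower number from compound 2 to compound 4 (0.70 log units; beyond the scatter) with phenyl in place of isopropyl. The earlier step at this position, with methoxy in place of isopropyl, was only a floor within the scatter, whereas these two steps put phenyl clearly lowest of the three groups compared here. The first of these steps gives only a minimum size, since compound 3 has a limit and not a number: the limit of > 10 mg/kg in this assay, at which 1 of the 4 values shown sits.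

Within the data shown here, with chlorine at this place, compound 1 gives 1 mg/kg; 1 mg/kg; 1 mg/kg (3 entries), and with phenyl, compound 4 gives 1 mg/kg, the same printed value, so an aromatic ring at this place is not the only group that reaches this value. Still open, on these data alone, is how a longer chain such as butyl, a pyridine ring or a phenyl ring bearing an amine would read at this place.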